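Replacing 1H-pyrazol-1-yl with 2-hydroxyphenyl in compound 2

This account rests on a few compounds, and the source may have more. Where it says the series, first, only, none or still open, it means among the compounds named here.

In a functional assay on G-361 cells (Homo sapiens) for inhibition, with a stated time of 72 h (on this read-out higher numbers stand for weaker inhibition and lower numbers for stronger inhibition), compound 1 (`COc1ccccc1-c1ccc(CNc2nc(NC3CCC(N)CC3)nc3c2ncn3C2CCCC2)cc1`) gives 545 nM, and compound 2 (`NC1CCC(Nc2nc(NCc3ccc(-n4cccn4)cc3)c3ncn(C4CCCC4)c3n2)CC1`) gives 220 nM, the lower of the two numbers. Compound 3 (`NC1CCC(Nc2nc(NCc3ccc(-c4ccccc4O)cc3)c3ncn(C4CCCC4)c3n2)CC1`) carries 2-hydroxyphenyl in place of 1H-pyrazol-1-yl on an aromatic carbon, para to a large group: 2-hydroxyphenyl in place of 1H-pyrazol-1-yl on an aromatic carbon. Within the data shown here, the only measured step that bears on this is a 2.5-fold lower number from compound 1 to compound 2 (0.39 log units; beyond the scatter), a modest step on leaving 2-methoxyphenyl for 1H-pyrazol-1-yl. A return to a substituted phenyl is therefore expected to reverse much of that step in this assay, and the expected change is a 1.7-fold higher number from compound 2 to compound 3 (0.24 log units; within the scatter). For compound 3 the estimated value is 380 nM, with an expected range of 130 nM to 1000 nM.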

Compound 3, half-maximal inhibitory concentration: 4150 nM
Estimate against measurement, compound 3: 11-fold (1.04 log units) below; the whole stated range lies below it.
By their numbers in this assay, from the lowest: compound 2; then compound 1; then compound 3.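

On the aromatic carbon para to a large group, in this assay, 2-hydroxyphenyl is far less well accepted than 1H-pyrazol-1-yl (a 19-fold higher number from compound 2 to compound 3 (1.28 log units; beyond the scatter)). The two substituted phenyls also do not behave alike: hydrogen in place of methyl on the oxygen gives a further clear change (a 7.6-fold higher number from compound 1 to compound 3 (0.88 log units; beyond the scatter)), so the phenyl ring alone does not set the value. No available evidence explains this loss.

From the compounds shown here alone, it remains open whether the free hydroxyl itself drives the rise in the number. Unsubstituted phenyl and 2-aminophenyl would bear on that question.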